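The compounds below may be only part of what the source reports. "The series", "measured", "known", "first", "only" and "open" are said of these compounds alone.

Measured compounds:
- compound 1 `N#Cc1cccc(C(=O)N2CCCC(C(=O)Nc3ccc(Cl)cc3)C2)c1`: 0%
- compound 2 `CS(=O)(=O)Nc1cccc(C(=O)N2CCCC(C(=O)Nc3ccc(Cl)cc3)C2)c1`: 3%
- compound 3 `CS(=O)(=O)c1cccc(C(=O)N2CCCC(C(=O)Nc3ccc(Cl)cc3)C2)c1`: 2%

All three numbers come from an ADME assay on PC-3 cells (Homo sapiens) for cytotoxicity, read by WST assay, tested at 100 uM; a lower number here means less inhibition, a higher number more inhibition at the concentration tested (going by the name of the read-out). In this assay compound 1 gives 0%, compound 2 gives 3% and compound 3 gives 2%. Compound 3 sits among the others: a number 1 percentage points lower from compound 2 to compound 3 (within the scatter) and a number 2 percentage points higher from compound 1 to compound 3 (within the scatter), so nothing here separates any of the three from the others, and none of them shows any appreciable effect at the concentration tested.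

The next compound is compound 4 `O=C(Nc1ccc(Cl)cc1)C1CCCN(C(=O)c2cccc(-c3cnco3)c2)C1`. It differs from compound 3 in one place: 1,3-oxazol-5-yl in place of methylsulfonyl on an aromatic carbon. The two steps that bear on this position are the ones into compound 3, namely a number 2 percentage points higher from compound 1 to compound 3 (within the scatter) and a number 1 percentage points lower from compound 2 to compound 3 (within the scatter); together with a number 3 percentage points higher from compound 1 to compound 2 (within the scatter) they show that three different groups at this position all leave the read-out at the bottom of the scale. Among the compounds with values here, no step in the set has yet put an aromatic ring at this position, so the new change is not directly covered, but nothing in the measured steps points to a move beyond the scatter.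

The expected step is a number 1 percentage points higher from compound 3 to compound 4 (within the scatter), that is, no change beyond the scatter. Compound 4 is therefore estimated at 3%, with a range of 0% to 15%.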

Compound 4, a percentage reported as inhibition, at one concentration (the size of the read-out at that concentration, not a potency): 0%
The estimate for compound 4 lay 3 percentage points above the measured number, within the range that was stated.
By their numbers in this assay, from the lowest: compounds 1, 4, 3 and 2 (each within the scatter of the next).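

In this assay, within the data shown here, the 1,3-oxazol-5-yl group brings a five-membered aromatic ring with 2 hetero atoms to this position for the first time, and the result is a number 2 percentage points lower from compound 3 to compound 4 (within the scatter), a number 3 percentage points lower from compound 2 to compound 4 (within the scatter) and no change at the digits printed from compound 1 to compound 4 (within the scatter). The position on the six-membered aromatic ring therefore accepts an aromatic ring as well as the nitrile, methanesulfonamido and methylsulfonyl groups without any step leaving the scatter, so all four compounds stay at the bottom of the scale and none can be ranked against the others. Nothing available accounts for this flat outcome, and the data give no reason for it.

Still open, going by these compounds, is whether an amine, a carboxylic acid or a longer chain at this position would move the read-out beyond the scatter, or whether the series stays flat whatever group stands there. Also open, on these data alone, is whether a change elsewhere on the shared core, such as replacing the chlorine on the other aromatic ring, would produce any measurable inhibition in this assay at all.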